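The compounds below may be only part of what the source reports. "The series", "measured", "known", "first", "only" and "open" are said of these compounds alone.

Compound 1 `CN(C)CCn1cnnc1-c1cc(Oc2ccc(NC(=O)N/N=C/c3ccc(O)c(Br)c3)cc2F)ccn1` is the compound with the lowest number of the two given in a functional assay on MKN-45 cells (Homo sapiens) for cytotoxicity, read by MTT assay, with a stated time of 72 h; a lower number here means a stronger inhibitor, a higher number a weaker inhibitor: it gives 1860 nM. Its nearest neighbour, compound 3 `Cn1cnnc1-c1cc(Oc2ccc(NC(=O)N/N=C/c3ccccc3)cc2F)ccn1`, gives 7610 nM in this assay. Compound 2 `Cn1ncnc1-c1cc(Oc2ccc(NC(=O)N/N=C/c3ccccc3)cc2F)ccn1` reaches only the assay limit of > 100000 nM in this assay, so no number is known for it. Among the compounds with values here, the one step measured between neighbours, an at least 13-fold lower number from compound 2 to compound 3 (1.11 log units; beyond the scatter), concerns the methyl-triazole part of the shared core, not the aryl group at the far end. Compound 4 `CN(C)CCn1cnnc1-c1cc(Oc2ccc(NC(=O)N/N=C/c3ccc(Cl)cc3Cl)cc2F)ccn1` differs from compound 1 there: 2,4-dichlorophenyl in place of 3-bromo-4-hydroxyphenyl on a carbon with a double bond to nitrogen. Within the data shown here, no measured step bears on this exchange, so no strong shift is expected. Compound 4 is therefore estimated at 2500 nM, between 800 nM and 8000 nM, an expected step of a 1.3-fold higher number from compound 1 to compound 4 (0.13 log units; within the scatter).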

Compound 4, half-maximal inhibitory concentration: 750 nM
Estimate against measurement, compound 4: 3.3-fold (0.52 log units) above; measured number outside the range, below it.
By their numbers in this assay, from the lowest: compound 4; then compound 1; then compound 3. At a limit, above all of these: compound 2.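

In this assay, within the data shown here, a 2.5-fold lower number from compound 1 to compound 4 (0.39 log units; beyond the scatter) is the first measured change at the aryl group on the carbon with a double bond to nitrogen, and it shows that this far end of the molecule also affects the number. It also shows that 2,4-dichlorophenyl, with 0 hydrogen-bond donors and 0 hydrogen-bond acceptors, can stand in for 3-bromo-4-hydroxyphenyl without loss. Nothing measured here accounts for the shift.

From the compounds shown here alone, the hydroxyl, the bromine and the two chlorines all change in one exchange, so their separate shares stay unknown. Going by these compounds, how a 4-methoxyphenyl or a 4-aminophenyl group would compare also remains open.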